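A Methanesulfonamide Added to the Pyridine of Compound 3

A few compounds are considered here, and "the series" means these few. Any claim that something is new, unique, unknown or untested is made for them only; others in the source may bear on it.

Of the compounds shown here, three have been measured in a functional assay for antagonist activity at transient receptor potential cation channel subfamily V member 1 (Homo sapiens), read by FLIPR; a lower number here means a stronger inhibitor, a higher number a weaker inhibitor. Compound 1 `C[C@@H]1CN(c2ncccc2C(F)(F)F)CCN1C(=O)Nc1ccc(C(F)(F)F)cc1` gives 17 nM in this assay. Compound 3 `CC(C)(C)c1ccc(NC(=O)c2ccc(-c3ccccn3)cc2)cc1` gives 11 nM in this assay, the lowest of the two numbers shown, but its gap to compound 1 lies within the usual scatter, so no order between the two can be stated. Compound 2 `O=C(Nc1ccccc1)c1ccc(-c2ncccc2C(F)(F)F)cc1` sits at > 4000 nM in this assay, which is a limit and not a number. No two of these compounds differ in one place only, so no single step can be read from them; compound 2 differs from compound 3 in more than one place, and the two values show only that one is a number and the other a limit (the limit of > 4000 nM in this assay, at which 1 of the 3 values shown sits).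

Compound 4 `CC(C)(C)c1ccc(NC(=O)c2ccc(-c3ncccc3NS(C)(=O)=O)cc2)cc1` is not yet measured. It differs from compound 3 by methanesulfonamido in place of hydrogen on an aromatic carbon. The expected step is a 14-fold higher number from compound 3 to compound 4 (1.13 log units; beyond the scatter), a move toward a weaker inhibitor that goes beyond the scatter. Compound 4 is therefore estimated at 150 nM, with a range from 25 nM to 1500 nM.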

Compound 4, half-maximal inhibitory concentration: 152 nM
For compound 4 the middle estimate is 1.0-fold (0.01 log units) below the measured one; the measured number falls inside the stated range.
By their numbers in this assay, from the lowest: compounds 3 and 1 (each within the scatter of the next); then compound 4. At a limit, above all of these: compound 2.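

In this assay, the series now holds its first change in one place, and it is a large one: methanesulfonamido in place of hydrogen gives a 14-fold higher number from compound 3 to compound 4 (1.14 log units; beyond the scatter). This shows that the position, ortho to a large group and two atoms from the ring nitrogen, is sensitive to what it carries, although compound 4 still gives a number, 152 nM. Nothing measured here gives a cause for this step.

One step cannot separate the effect of this particular group from that of any substituent at this position, so a plain amine or an acetamido group in the same place would be needed to tell them apart. On these data alone, it also remains open whether an N-methyl methanesulfonamido group, which lacks the hydrogen on nitrogen, would give a similar step.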